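This account rests on a few compounds, and the source may have more. Where it says the series, first, only, none or still open, it means among the compounds named here.

Compound 1, `CC1CCC(C(=O)N2CC(c3nc(-c4cccc(Cl)c4)no3)C2)CC1`, in an assay on HEK293 cells for negative allosteric modulation of metabotropic glutamate receptor 5 (Homo sapiens), read by FLIPR (a higher number here means a weaker inhibitor, a lower number a stronger inhibitor), gives > 10000 nM, which is a limit of the assay rather than a number. Compound 2, `CC1CCN(C(=O)N2CC(c3nc(-c4cccc(Cl)c4)no3)C2)C1`, in this assay gives > 10000 nM, again a limit of the assay.

Within the data shown here, compound 2 therefore stands at the limit in this assay, and its neighbour sits there too; the single step between measured compounds, a step that the two limits leave unreadable from compound 1 to compound 2, has no readable size because the limit of > 10000 nM in this assay, at which 2 of the 2 values shown sit, holds for both of its ends. Compound 3, `O=C(N1CCCCCC1)N1CC(c2nc(-c3cccc(Cl)c3)no2)C1`, carries a change of the same kind on the same carbonyl carbon: azepan-1-yl in place of 3-methylpyrrolidin-1-yl on a carbonyl carbon. Among the measured compounds shown here, the only measured step, a step that the two limits leave unreadable from compound 1 to compound 2, bears on this change in place but tells nothing about its size or direction, so no step beyond the scatter can be predicted in either direction, and the most that the numbers support is that the ring swap on this carbon has not yet produced a readable inhibitor. Compound 3 is therefore expected to remain near the limit, with an estimated value of 15000 nM in a range from 5000 nM to 50000 nM. This estimate means a step that the limit leaves unreadable from compound 2 to compound 3, expected to stay within the scatter.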

Compound 3, half-maximal inhibitory concentration: > 10000 nM
Compound 3 ended at the assay's limit; the forecaster's own chance of this, stated with the estimate: 75%; the middle value lies beyond the limit too.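

Compound 3 sits at the limit of the assay, as do compound 1 and compound 2, so no size or direction can be read for any step among these three compounds: the limit of > 10000 nM in this assay, at which 3 of the 3 values shown sit.

The compounds shown leave open whether any group on this carbonyl carbon gives a measurable inhibitor, and how 4-methylcyclohexyl, 3-methylpyrrolidin-1-yl and azepan-1-yl truly rank.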